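Aryl ether in place of piperidinyl ether on the shared core

A few compounds are considered here, and "the series" means these few. Any claim that something is new, unique, unknown or untested is made for them only; others in the source may bear on it.

Measured so far in a functional assay on K562 cells (Homo sapiens) for antiproliferative activity, read by CellTiter-Glo and CCK-8 assay, with a stated time of 72 h; on this read-out lower numbers stand for stronger inhibition of growth and higher numbers for weaker inhibition of growth:
compound 1 `Cc1ccc(NC(=O)c2cccc(C(F)(F)F)c2)cc1N1Cc2cnc(Nc3ccc(C)c(C(F)(F)F)c3)nc2N(C)C1=O`: 29 nM
compound 2 `Cc1ccc(NC(=O)c2cccc(C(F)(F)F)c2)cc1N1Cc2cnc(OC3CCNCC3)nc2N(C)C1=O`: 220 nM

Within the data shown here, compound 2 stands at the higher of the two numbers, with compound 1 the only neighbour for comparison. Among the measured compounds shown here, the one step that bears on the present question is a 7.6-fold higher number from compound 1 to compound 2 (0.88 log units; beyond the scatter), which shows what happens when an aromatic amine substituent gives way to a saturated amine ether on that aromatic carbon.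

Compound 3 `Cc1ccc(Oc2ncc3c(n2)N(C)C(=O)N(c2cc(NC(=O)c4cccc(C(F)(F)F)c4)ccc2C)C3)cc1N` carries the change (3-amino-4-methylphenyl in place of piperidin-4-yl on an oxygen on an aromatic ring). The oxygen link of compound 2 is kept, while the group on it is again an aromatic ring, as in compound 1. The available step points toward a lower number for compound 3 than for compound 2, though the oxygen link remains, so the full return to the value of compound 1 is not assumed. The expected step is a 2.8-fold lower number from compound 2 to compound 3 (0.44 log units; beyond the scatter). Compound 3 is therefore estimated at 80 nM, within 25 nM to 250 nM.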

Compound 3, concentration for 50% growth inhibition: 13 nM
The estimate for compound 3 lay 6.2-fold (0.79 log units) above the measured number, and the stated range ends above it.
By their numbers in this assay, from the lowest: compound 3; then compound 1; then compound 2.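

In this assay, the oxygen link on the aromatic carbon does not by itself carry the loss seen with compound 2: with 3-amino-4-methylphenyl in place of piperidin-4-yl on that oxygen, the result is a 17-fold lower number from compound 2 to compound 3 (1.23 log units; beyond the scatter), a large step beyond the scatter. The aromatic ether also goes past the aromatic amine, with a 2.2-fold lower number from compound 1 to compound 3 (0.35 log units; beyond the scatter) in a modest step, so at this position an aromatic ring on oxygen is compatible with stronger growth inhibition than either earlier group gave. No supporting data bear on why this change has this effect.

The step between compound 1 and compound 3 changes the link and the ring substituents together, so their shares cannot be separated. From the compounds shown here alone, it also remains open how much depends on the amino group, which a plain phenoxy or a 3-(trifluoromethyl)phenoxy group at this position would test.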